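The source may report more compounds than this note shows. Statements on the series, on what has been measured and on what is new or still open speak of the compounds shown alone.

Measured so far:
compound 1, `CCOC(=O)C1=C(Nc2ccccc2)S/C(=C\c2ccccc2C(F)(F)F)C1=O` — < 10%
compound 2, `CCOC(=O)C1=C(Nc2ccc(OC)cc2)S/C(=C\c2ccc[nH]2)C1=O` — < 10%

Both values come from a functional assay on MCF7 cells (Homo sapiens) for inhibition, read by MTT assay, with a stated time of 72 h, tested at 10 uM; a lower number here means less inhibition, a higher number more inhibition at the concentration tested (going by the name of the read-out). For compound 1 the value < 10% is a limit of the assay, not a number. For compound 2 the value < 10% is likewise a limit. Compound 2 thus stands at the floor of what has been seen in the series: the limit of < 10% in this assay, at which 2 of the 2 values shown sit. Compound 3, `CCOC(=O)C1=C(Nc2cccc([N+](=O)[O-])c2)S/C(=C\c2ccc[nH]2)C1=O`, is not yet measured. It differs from compound 2 in one place: 3-nitrophenyl in place of 4-methoxyphenyl on an amine nitrogen. Among the compounds with values here, no step between measured compounds is available, so the size of this change in this assay is unknown. Compound 2 sits at a limit, so any step would only become visible if compound 3 rose beyond the scatter. Expectation: none beyond the scatter, with compound 3 most likely reported as a limit again. Compound 3 is estimated at 8%, range 0% to 25%. The step this implies in this assay is expected at a step that the limit leaves unreadable from compound 2 to compound 3.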

Compound 3, a percentage reported as inhibition, at one concentration (the size of the read-out at that concentration, not a potency): 27.4%
Estimate against measurement, compound 3: 19.4 percentage points below; the measured number lies above the stated range.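

In this assay the aryl group on the amine nitrogen proves to be a place where a change can be read: 3-nitrophenyl in place of 4-methoxyphenyl gives a number at least 17.4 percentage points higher from compound 2 to compound 3 (beyond the scatter). Compound 3 at 27.4% is the first compound shown with a number rather than a limit, though this is still a read-out at one concentration and not a potency. Compound 2 remains at a limit of the assay, and such limits still set the low end of the series: the limit of < 10% in this assay, at which 2 of the 3 values shown sit.

The compounds shown leave open whether the step belongs to the nitro group itself or to where it sits on the ring, since both differ together. Also open, on these data alone, is how an amine or a carboxylic acid in place of the nitro group would read at this position.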